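Trading an ester-bearing amide for a methoxy(methyl)amide

This account rests on a few compounds, and the source may have more. Where it says the series, first, only, none or still open, it means among the compounds named here.

Measured compounds:
Compound 1, `COC(=O)c1ccc(NC(=O)[C@H]2CC=C(CCC=C(C)C)C[C@@H]2c2ccccc2)cc1`, gives > 23000 nM in an assay on isolated protein for inhibition of Apoptosis regulator Bcl-2 (Homo sapiens), read by fluorescence polarization, with stated times of 5 min and 10 min; a higher number here means a weaker inhibitor, a lower number a stronger inhibitor; this is a limit of the assay rather than a number.
Compound 2, `COC(=O)CCNC(=O)[C@H]1CC=C(CCC=C(C)C)C[C@@H]1c1ccccc1`, gives 3100 nM in this assay.

Within the data shown here, compound 2 thus holds the only number among the two values shown, the other value being a limit: the limit of > 23000 nM in this assay, at which 1 of the 2 values shown sits. Compound 3, `CON(C)C(=O)[C@H]1CC=C(CCC=C(C)C)C[C@@H]1c1ccccc1`, has not yet been measured. The change from compound 2 to compound 3 is methoxy(methyl)amino in place of (2-(methoxycarbonyl)ethyl)amino on a carbonyl carbon. Among the measured compounds shown here, the one measured step bears on the same amide nitrogen: an at least 7.4-fold lower number from compound 1 to compound 2 (0.87 log units; beyond the scatter). That step shows that the inhibition responds to what sits on that nitrogen, but it runs from a larger aromatic group to a smaller, donor-bearing chain, whereas the present change removes the chain and its hydrogen-bond donor altogether and leaves a small methoxy(methyl)amino group. For the measured compounds named here, no measured step covers a change of this kind, so the direction is uncertain; a step beyond the scatter in either direction seems possible, and weaker inhibition is expected as the somewhat more likely outcome. For compound 3 the expected step is a 2.9-fold higher number from compound 2 to compound 3 (0.46 log units; beyond the scatter). Compound 3 is therefore estimated at 9000 nM, within an expected range of 2000 nM to 40000 nM.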

Compound 3, inhibition constant: 300 nM
Compound 3: the middle estimate sits 30-fold (1.48 log units) above what was measured; measured number below the stated range.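

The methyl ester on the chain of compound 2 is not needed for inhibition of Bcl-2 binding at this position: in this assay, swapping (2-(methoxycarbonyl)ethyl)amino for methoxy(methyl)amino on the carbonyl carbon gives a 10-fold lower number from compound 2 to compound 3 (1.01 log units; beyond the scatter) and leaves no ester in that group at all. The amide hydrogen is not needed either, since methoxy(methyl)amino has no hydrogen-bond donor, whereas the step from compound 1 to compound 2 alone could not show this as both compounds keep that hydrogen. The data shown include no measurement that explains why this smaller group gives the lower number.

This one change removes the ester, the amide hydrogen and part of the chain together, so the compounds shown cannot say which of these losses matters, or whether the methoxy oxygen of the new group contributes anything. Dimethylamino, which lacks that oxygen, and methoxyamino, which keeps the amide hydrogen, would pull these effects apart, while a longer alkoxy group such as ethoxy(methyl)amino would test how much room this position allows.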